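The source may report more compounds than this note shows. Statements on the series, on what has been measured and on what is new or still open speak of the compounds shown alone.

Working notes on the series. In a functional assay on HEK293 cells for agonist activity at D(4) dopamine receptor (Homo sapiens), read by FLIPR (on this read-out higher numbers stand for larger maximal responses and lower numbers for smaller maximal responses), compound 1 `O=C(NCN1CCC(c2cccc[n+]2[O-])CC1)c1cnccc1Cl` gives 44%. Compound 2 `COc1cccc(C)c1NC(=O)CN1CCC(c2cccc[n+]2[O-])CC1` gives 56% in this assay. Compound 3 `Cc1cccc(Cl)c1NC(=O)CN1CCC(c2ccccn2)CC1` gives 70% in this assay, the highest of the three numbers: the nearest is compound 2, lower by a gap beyond the usual scatter, and the furthest is compound 1, lower by a gap also beyond the scatter. Going by the values given here, no two of the three measured compounds differ in only one place, so no measured single step stands behind the comparison that follows.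

Compound 4 `COc1cccc(C)c1NC(=O)CN1CCC(c2ccccn2)CC1` has not yet been measured in this assay. It differs from compound 3 in one place: methoxy in place of chloro on an aromatic carbon. Nothing measured shows how this exchange on its own moves the maximal response, since compound 2 and compound 4 differ elsewhere as well. A moderate downward step is expected, a number 12 percentage points lower from compound 3 to compound 4 (beyond the scatter), on the ground that compound 2 with 56% stands below compound 3 with 70%. The expected step is small enough that compound 4 should sit between those two numbers. Compound 4 is therefore expected to give 58% in this assay, with a range from 40% to 76%.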

Compound 4, largest response reached (reported as efficacy), in percent of the reference or control that the assay uses: 69%
Compound 4: the middle estimate sits 11 percentage points below what was measured, and the stated range covers the measured number.
By their numbers in this assay, from the lowest: compound 1; then compound 2; then compounds 4 and 3 (each within the scatter of the next).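

In this assay, going by these compounds alone, methoxy in place of chloro on an aromatic carbon, ortho to a large group and meta to a methyl group, gives a number 1 percentage points lower from compound 3 to compound 4 (within the scatter), so this is the first single exchange read at this position and the two groups cannot be told apart there on this read-out. The second single step gives a number 13 percentage points higher from compound 2 to compound 4 (beyond the scatter), with the group of 6 heavy atoms in place of the group of 7 heavy atoms on a saturated ring carbon, so in this pair a change at that carbon has a measurable size, unlike the exchange on the aromatic carbon. Nothing at hand explains the size of either step.

Going by these compounds, the aromatic position is covered by chloro and methoxy alone, so it remains open whether a much larger or differently charged group there, such as a trifluoromethyl, an amine or a carboxylic acid, would also stand level with them. On these data alone, it is also open whether the methoxy and chloro exchange reads the same with the group of 7 heavy atoms on the saturated ring carbon, since both compounds of that step carry the group of 6 heavy atoms.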